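Anilide swap on the compound 2 scaffold

A few compounds are considered here, and "the series" means these few. Any claim that something is new, unique, unknown or untested is made for them only; others in the source may bear on it.

In a functional assay on A549 cells (Homo sapiens) for cytotoxicity, read by MTT assay, with a stated time of 72 h (a higher number here means a weaker inhibitor, a lower number a stronger inhibitor), compound 1 (`Cc1ccc(NC(=O)CN2CCN(c3nnc(Cc4ccncc4)c4ccccc34)CC2)c(C)c1`) gives 45000 nM and compound 3 (`O=C(CN1CCN(c2nnc(Cc3ccncc3)c3ccccc23)CC1)Nc1cc(C(F)(F)F)ccc1Cl`) gives 1850 nM. Compound 2 (`COc1ccc(NC(=O)CN2CCN(c3nnc(Cc4ccccc4)c4ccccc34)CC2)cc1OC`) is recorded as "not active" (no number reported). With no single number, compound 2 has no exact place on this scale, and no step size can be calculated from it.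

Compound 4 (`O=C(CN1CCN(c2nnc(Cc3ccccc3)c3ccccc23)CC1)Nc1ccc(F)c(Cl)c1`) carries 3-chloro-4-fluorophenyl in place of 3,4-dimethoxyphenyl on an amide-type nitrogen. Its core is the same as that of compound 2.

Among the measured compounds shown here, only one measured step bears on this change, and it is also an exchange of the aryl group on the amide nitrogen: a 24-fold lower number from compound 1 to compound 3 (1.39 log units; beyond the scatter). This large step, beyond the scatter, shows that the group at this place can move the read-out substantially. It is weak support, however. For the measured compounds named here, it involves different aryl groups, and no measured step lies on the core of compound 2 and compound 4.

A shift towards a lower number in this assay is expected, of a size that cannot be fixed and with a real chance that no number is obtained. The expected value for compound 4 is 10000 nM, within an estimated range of 2000 nM to 50000 nM.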

Compound 4, half-maximal inhibitory concentration: "not active" (no number reported)
The entry for compound 4 holds no number; no gap can be computed for the estimate.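

In this assay compound 2 gives "not active" (no number reported) and compound 4 gives "not active" (no number reported), so no step can be read between these two compounds. The compounds shown leave open whether any aryl group on the amide nitrogen of this shared core gives a number in this read-out. No supporting evidence bears on this result.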